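Removing the acetamido group from a weak sulfonamide

The compounds below may be only part of what the source reports. "The series", "measured", "known", "first", "only" and "open" are said of these compounds alone.

Two sulfonamides have been measured in an assay on isolated protein for inhibition of NAD-dependent protein deacylase sirtuin-6 (Homo sapiens), read by luminescence; a lower number here means a stronger inhibitor, a higher number a weaker inhibitor. Compound 1 `O=c1[nH]c(=O)c2cc(S(=O)(=O)Nc3ccc(Oc4cccnc4)cc3)ccc2[nH]1` gives 136000 nM in this assay. Compound 2 `CC(=O)Nc1ccc(S(=O)(=O)Nc2ccc(Oc3cccnc3)cc2)cc1` gives 242000 nM in this assay, and these two numbers lie within the scatter of each other, so no order between compound 1 and compound 2 can be read from them. Compound 3 `O=S(=O)(Nc1ccc(Oc2cccnc2)cc1)c1ccccc1` has not yet been measured. It differs from compound 2 in one place: hydrogen in place of acetamido on an aromatic carbon. Going by the values given here, no measured pair shows what this change does, and both measured compounds sit at weak inhibition, so the step is expected to be small, in either direction or none beyond the scatter; in this assay the step of a 1.1-fold higher number from compound 2 to compound 3 (0.03 log units; within the scatter) is the one estimated here. On that basis compound 3 is expected to give about 260000 nM in this assay, with a plausible range from 100000 nM to 650000 nM.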

Compound 3, half-maximal inhibitory concentration: 300000 nM
Beside the measured number, compound 3's estimate is 1.2-fold (0.06 log units) below it; measured number inside the range.
By their numbers in this assay, from the lowest: compounds 1, 2 and 3 (each within the scatter of the next, the first and the last beyond it).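

Going by these compounds alone, exchanging the acetamido group for hydrogen, para to a large group, gives a 1.2-fold higher number from compound 2 to compound 3 (0.09 log units; within the scatter) in this assay and is the first measured change at this position. The pair shows that all 4 heavy atoms of acetamido, with its hydrogen-bond donor and acceptor, can leave this aromatic carbon without a shift beyond the scatter, at least at this weak level of inhibition. No supporting data explain this result.

Still open, going by these compounds, is whether this position responds to any other group, such as an amine, a carboxylic acid or a longer acyl chain in place of acetamido. This single pair also leaves open whether the same exchange would be as silent on a compound that inhibits more strongly.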